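Series at the limit: the step to compound 4

A few compounds are considered here, and "the series" means these few. Any claim that something is new, unique, unknown or untested is made for them only; others in the source may bear on it.

In a functional assay on UACC-62 cells (Homo sapiens) (a higher number here means a weaker inhibitor of growth, a lower number a stronger inhibitor of growth), compound 3 (`O=S(=O)(/C=C/c1ccc(Br)cc1)Cc1ccc(Nc2ncnc3ccc(Br)cc23)cc1`) gives > 100000 nM as a limit and not a number. Compound 1 (`O=S(=O)(/C=C/c1ccc(Br)cc1)Cc1ccc(Nc2ncnc3ccccc23)cc1`) gives > 100000 nM as a limit too. Compound 2 (`O=S(=O)(/C=C/c1ccc(F)cc1F)Cc1ccc(Nc2ncnc3ccccc23)cc1`) also gives > 100000 nM as a limit. Among the measured compounds shown here, the position so far is the limit of > 100000 nM in this assay, at which 3 of the 3 values shown sit, and nothing finer can be read from it.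

The change to compound 4 (`O=S(=O)(/C=C/c1ccc(Cl)cc1Cl)Cc1ccc(Nc2ncnc3ccc(Br)cc23)cc1`) puts 2,4-dichlorophenyl in place of 4-bromophenyl on a double-bonded chain carbon bound to a double-bonded chain carbon and the rest of compound 3 stays.

The nearest measured change is a step that the two limits leave unreadable from compound 1 to compound 2 and it replaces the same 4-bromophenyl with 2,4-difluorophenyl. The other is a step that the two limits leave unreadable from compound 1 to compound 3 and it sets bromo in place of hydrogen on an aromatic carbon. Neither gives a size or a direction, so no step beyond the scatter is expected in this assay on this evidence.

The estimated change is a number no higher from compound 3 to compound 4 (the limit leaves the size open) and it may well go unreadable again. For compound 4 the estimated value is 100000 nM with an expected range from 30000 nM to 100000 nM and a report of the limit alone is the likeliest outcome.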

Compound 4, concentration for 50% growth inhibition: 2000 nM
The estimate for compound 4 lay 50-fold (1.70 log units) above the measured number; measured number below the stated range.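

In this assay, the group on the double-bonded chain carbon is now a place where a change can be read: 2,4-dichlorophenyl in place of 4-bromophenyl gives an at least 50-fold lower number from compound 3 to compound 4 (1.69 log units; beyond the scatter). Among the compounds shown here, the steps among the earlier compounds cannot be read, so this is the first size and direction available for any change. Compound 4 is also the only compound shown with a number and not a limit: the limit of > 100000 nM in this assay, at which 3 of the 4 values shown sit.

From the compounds shown here alone, whether the step depends on the bromo on the core of compound 4 stays open. So does how an amine or a carboxylic acid in place of 2,4-dichlorophenyl would read in this assay, and whether any such group would keep a value clear of the limit.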